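The source may report more compounds than this note shows. Statements on the series, on what has been measured and on what is new or still open speak of the compounds shown alone.

Working notes on the series.

Two members of the series have been measured in a functional assay on the whole organism for inhibition, with Mus musculus as the target, at a dose of 10 mg/kg (a higher number here means more inhibition at the dose given (going by the name of the read-out), a lower number less inhibition), so far. Compound 1 `CCCOCC1=CS(=O)(=O)c2ccccc2C1=O` carries a propoxymethyl side chain on the shared core; in this assay compound 1 gives 99.9%. Compound 2 `O=C1C(COCCBr)=CS(=O)(=O)c2ccccc21` differs from it only by bromo in place of methyl on a saturated chain carbon, two bonds along the chain from an oxygen on a saturated carbon; in this assay compound 2 gives 100%. Among the compounds with values here, the single measured step, a number 0.1 percentage points higher from compound 1 to compound 2 (within the scatter), lies within the scatter, so the two are not distinguishable on these numbers. Compound 2 stands highest of the two numbers, with compound 1 nearest, but the gap means nothing beyond the scatter.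

Compound 3 `O=COCC1=CS(=O)(=O)c2ccccc2C1=O` is not yet measured. It differs from compound 2 in this way: formyl in place of 2-bromoethyl on an oxygen on a saturated carbon. Within the data shown here, no measured step bears directly on this change; the only step, from compound 1 to compound 2, touched the far end of the chain and was flat. Both measured compounds give high numbers in this assay, so the expected step of a number 12 percentage points lower from compound 2 to compound 3 (beyond the scatter) is small or none beyond the scatter, with the uncertainty on the downward side. For compound 3 the estimate in this assay is 88%, with a range from 55% to 100%.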

Compound 3, a percentage reported as inhibition, in the whole organism at one dose (the size of the read-out at that dose, not a potency): 91.6%
For compound 3 the middle estimate is 3.6 percentage points below the measured one; the range from low to high includes it.
By their numbers in this assay, from the lowest: compounds 3, 1 and 2 (each within the scatter of the next).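

The change now reaches the whole group on the oxygen on a saturated carbon, not only the far end of the chain: in this assay the formyl compound shows a number 8.4 percentage points lower from compound 2 to compound 3 (within the scatter) and also a number 8.3 percentage points lower from compound 1 to compound 3 (within the scatter) as the step from the propyl ether. On these numbers, then, 2-bromoethyl, propyl and formyl at this position cannot be told apart, and the alkyl chain can give way to a shorter group with a double bond and a hydrogen-bond acceptor while the read-out stays in the same range; as this is the size of the effect at one dose and not a potency, real differences between the three compounds could go unseen. No supporting data bear on why the three compounds read alike.

Within the data shown here, still open is whether an amine, a carboxylic acid or a longer chain on this oxygen would stay within the same range or bring the first step beyond the scatter. Also open, as far as these compounds go, is whether compound 2 and compound 3 would separate at a lower dose, and whether the free hydroxyl, with nothing on the oxygen, would read like them.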